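The compounds below may be only part of what the source reports. "The series", "measured", "known", "first", "only" and "open" are said of these compounds alone.

Measured in an ADME assay on HEK293 cells (Homo sapiens) for cytotoxicity, with a stated time of 6 h (a higher number here means that more compound is tolerated, a lower number that less compound is tolerated), on the shared core:
Compound 1 `CCCCNc1nc(N)nc2cccc(OC)c12` gives > 25000 nM as a limit
Compound 2 `CCCCNc1nc(N)nc2cccc(CCc3ccccc3)c12` gives > 25000 nM as a limit
Compound 3 `CCCCNc1nc(N)nc2cccc(C(=O)NC(C)C)c12` gives > 25000 nM as a limit

Compound 3 has no number, and its place is the limit of > 25000 nM in this assay, at which 3 of the 3 values shown sit, together with the other two compounds. Compound 4 `CCCCNc1nc(N)nc2cccc(C(=O)N[C@H](C)c3ccccc3)c12` differs from compound 3 as follows: 1-phenylethyl in place of isopropyl on an amide-type nitrogen and so carries 1-phenylethyl in place of isopropyl on an amide-type nitrogen. Within the data shown here, the steps that bear on this are a step that the two limits leave unreadable from compound 1 to compound 3 and a step that the two limits leave unreadable from compound 2 to compound 3 and neither has a readable size. Among the measured compounds shown here, with no sized step to go on, no change in this assay beyond the scatter is expected, in either direction. The expected move is a number no higher from compound 3 to compound 4 (the limit leaves the size open) in this estimate. Compound 4 is estimated at 25000 nM with an expected range from 12000 nM to 50000 nM as its span.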

Compound 4, half-maximal cytotoxic concentration: > 25000 nM
Compound 4 ended at the assay's limit (the forecaster's own chance of this, stated with the estimate: 80%); the middle value lies on the limit itself.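

No step can be read from compound 3 to compound 4, because both values are limits and not numbers: the limit of > 25000 nM in this assay, at which 4 of the 4 values shown sit.

The compounds shown leave open where the actual value of any of them lies in this assay.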